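The source may hold more compounds than are shown below. What is called first, only, known or untested is meant among the compounds shown, and "the series" means these compounds.

Compound 1 `C=C1C[C@]23C[C@@]1(O)CC[C@H]2c1cc(Br)c(O)c(C)c1[C@@H]3Cn1cc(-c2ccccc2)nn1` and compound 2 `C=C1C[C@]23C[C@@]1(O)CC[C@H]2c1cc(Br)c(O)c(C)c1[C@@H]3Cn1cc(-c2ccccn2)nn1` share one core and differ only in the aromatic group attached to an aromatic carbon of that core. In a functional assay on A549 cells (Homo sapiens) for cytotoxicity, read by MTT assay, with a stated time of 4 days (on this read-out lower numbers stand for stronger inhibition and higher numbers for weaker inhibition), compound 1 gives only a limit of the assay, > 20000 nM. In this assay compound 2 likewise gives only a limit, > 20000 nM. The step that the two limits leave unreadable from compound 1 to compound 2 cannot be read, because both values sit at the limit of > 20000 nM in this assay, at which 2 of the 2 values shown sit. Compound 2 therefore stands at the limit, with nothing to set it apart from compound 1. Compound 3 `C=C1C[C@]23C[C@@]1(O)CC[C@H]2c1cc(Br)c(O)c(C)c1[C@@H]3Cn1cc(-c2ccc(C(F)(F)F)cc2)nn1` carries the change (4-(trifluoromethyl)phenyl in place of pyridin-2-yl on an aromatic carbon). Among the compounds with values here, no measured step bears readably on this change, so the only guide is that both known compounds are at the limit. Compound 3 is expected to give 30000 nM in this assay, within 10000 nM to 100000 nM. The estimated step that the limit leaves unreadable from compound 2 to compound 3 is expected to stay within the scatter, most likely as another limit.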

Compound 3, half-maximal inhibitory concentration: 9280 nM
Estimate against measurement, compound 3: 3.2-fold (0.51 log units) above; measured number below the stated range.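

In this assay, within the data shown here, 4-(trifluoromethyl)phenyl on the aromatic carbon of the five-membered aromatic ring gives the first readable step at this position, an at least 2.1-fold lower number from compound 2 to compound 3 (0.33 log units; beyond the scatter), with pyridin-2-yl as the group that leaves. Set against the phenyl group, trifluoromethyl in place of hydrogen on an aromatic carbon gives an at least 2.1-fold lower number from compound 1 to compound 3 (0.33 log units; beyond the scatter), so this one added group is enough to bring the number into the readable range of the assay. Compound 3 alone stands clear of the limit that holds the other two: the limit of > 20000 nM in this assay, at which 2 of the 3 values shown sit.

The step from phenyl to pyridin-2-yl still cannot be read, so nothing can be said about that exchange. From the compounds shown here alone, it also remains open whether a chlorine, a methoxy group or an amine in place of the trifluoromethyl would lower the number in the same way.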